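Chloro-fluoro aryl variant of compound 1 in hepatocytes

This account rests on a few compounds, and the source may have more. Where it says the series, first, only, none or still open, it means among the compounds named here.

Going by the values given here, compound 1 `COc1cc(N(CC2CC2)c2ccccc2)cnc1C(=O)[C@H]1C[C@@H]1C(=O)O` is one of two compounds measured so far. In an ADME assay on cells (Hepatocyte, Homo sapiens) for metabolic stability, read by LC-MS, with a stated time of 60 min, tested at 1 uM (a higher number here means faster removal of the compound, a lower number slower removal), compound 1 gives 3 uL/min, nominally the lower of the two figures, while compound 2 `CCN(c1cnc(C(=O)[C@H]2C[C@@H]2C(=O)O)c(OC)c1)c1ccc(F)c2ccccc12` gives 3.8 uL/min; the gap between them is within the scatter, so the two are treated as equivalent. Compound 3 `COc1cc(N(CC2CC2)c2cc(Cl)ccc2F)cnc1C(=O)[C@H]1C[C@@H]1C(=O)O` differs from compound 1 in one place: 5-chloro-2-fluorophenyl in place of phenyl on a nitrogen on an aromatic ring. Among the compounds with values here, no measured pair covers this change, so the step of no change at the digits printed from compound 1 to compound 3 (within the scatter) is expected to stay within the scatter, with no clear direction. Compound 3 is accordingly estimated at 3 uL/min, within a range of 1.2 uL/min to 7.5 uL/min.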

Compound 3, intrinsic clearance in a liver preparation (reported as CLH), per the amount of preparation that the assay uses: 1.3 uL/min
The estimate for compound 3 lay 2.3-fold (0.36 log units) above the measured number; the measured number falls inside the stated range.
By their numbers in this assay, from the lowest: compound 3; then compounds 1 and 2 (each within the scatter of the next).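

In this assay, going by these compounds alone, 5-chloro-2-fluorophenyl in place of phenyl on a nitrogen on an aromatic ring gives a 2.3-fold lower number from compound 1 to compound 3 (0.36 log units; beyond the scatter), the only step so far that lies beyond the scatter. This position therefore registers in this read-out, which the two earlier compounds could not show. Nothing at hand explains the step.

The compounds shown do not separate the chlorine from the fluorine, as neither appears alone on the phenyl. Going by these compounds, how a nitrile or an amine on that phenyl would read remains open.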